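Bromo in Place of Methyl on Two Related Cores

The source may hold more compounds than are shown below. What is called first, only, known or untested is meant among the compounds shown, and "the series" means these compounds.

Compound 1 `COC(=O)[C@@]1(C)CCC=C2[C@@H]1CC[C@@H](C)[C@]2(C)Cc1c(C)[nH]c2ccc(C)cc12` and compound 2 `COC(=O)[C@@]1(C)CCC=C2[C@@H]1CC[C@@H](C)[C@]2(C)Cc1c(C)[nH]c2ccc(Br)cc12` share one core. In a functional assay on HeLa cells (Homo sapiens) for inhibition, read by sulforhodamine B assay, with a stated time of 48 h (a lower number here means a stronger inhibitor of growth, a higher number a weaker inhibitor of growth), compound 1 gives 17000 nM, and compound 2 gives 11000 nM. The change between them is bromo in place of methyl on an aromatic carbon, and it made a step of a 1.5-fold lower number from compound 1 to compound 2 (0.19 log units; within the scatter). Compound 3 `COC(=O)[C@@]1(C)CC[C@@H]2C3=C1CC[C@@H](C)[C@]3(C)C[C@@H]1c3cccc(C)c3N[C@H]21` is built on a different core; the difference between the two cores is not broken down here. In this assay compound 3 gives 22000 nM. Compound 4 `COC(=O)[C@@]1(C)CC[C@@H]2C3=C1CC[C@@H](C)[C@]3(C)C[C@@H]1c3cccc(Br)c3N[C@H]21` carries the same kind of change, (bromo in place of methyl on an aromatic carbon), but the surroundings differ: here the aromatic carbon is ortho to a fused ring and meta to a fused ring, part of a fused or bridged system of five rings, whereas in compound 2 it is meta to a fused ring and para to a fused ring, part of a fused or bridged system of two rings. Because the earlier step of a 1.5-fold lower number from compound 1 to compound 2 (0.19 log units; within the scatter) stayed within the scatter, a similar small step is expected here, a 1.5-fold lower number from compound 3 to compound 4 (0.17 log units; within the scatter). Compound 4 is therefore estimated at 15000 nM, with a likely range from 7000 nM to 32000 nM.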

Compound 4, concentration for 50% growth inhibition: 22000 nM
The estimate for compound 4 lay 1.5-fold (0.17 log units) below the measured number; low and high end bracket the measured number.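

In this assay, bromo in place of methyl on an aromatic carbon gave no change at the digits printed from compound 3 to compound 4 (within the scatter). Set beside the earlier step, the same change reads alike on the two cores: the same change on two cores in this assay, a 1.5-fold lower number (0.19 log units; within the scatter) from compound 1 to compound 2 and no change at the digits printed (within the scatter) from compound 3 to compound 4, 1.5-fold (0.19 log units) apart, within the scatter of two such steps This shows that the swap stays within the scatter on both cores, but it does not show that bromo and methyl are truly equal on either core, or that other changes would carry from one core to the other in the same way.

The compounds shown leave open whether a different kind of group at this aromatic carbon, such as an amine or a carboxylic acid, would move the number beyond the scatter. They also leave open what separate parts of the two cores contribute.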